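The compounds below may be only part of what the source reports. "The series", "measured", "known", "first", "only" and "open" are said of these compounds alone.

Measured compounds in a functional assay on PC-3 cells (Homo sapiens) for antiproliferative activity, read by MTT assay, with a stated time of 24 h; a lower number here means a stronger inhibitor, a higher number a weaker inhibitor:
Compound 1, `CCn1c(C(=O)N[C@@H](C)C(=O)OC)ccc1C(CC)(CC)c1ccc(OCS(=O)(=O)c2ccccc2)c(C)c1`, gives > 50000 nM, which is a limit of the assay rather than a number.
Compound 2, `CCn1c(C(=O)NC2(CO)CC2)ccc1C(CC)(CC)c1ccc(OCS(=O)(=O)c2ccccc2)c(C)c1`, gives 3560 nM.
Compound 3, `CCn1c(C(=O)N[C@@H](C)C(=O)O)ccc1C(CC)(CC)c1ccc(OCS(=O)(=O)c2ccccc2)c(C)c1`, gives 16800 nM.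

Compound 1 therefore stands only as a limit among the three values shown: the limit of > 50000 nM in this assay, at which 1 of the 3 values shown sits. Compound 2 and compound 3 both give numbers, and the step of a 4.7-fold higher number from compound 2 to compound 3 (0.67 log units; beyond the scatter) separates them.

The account follows the step from compound 1 to the unmeasured compound 4, `CCn1c(C(=O)NCC(=O)O)ccc1C(CC)(CC)c1ccc(OCS(=O)(=O)c2ccccc2)c(C)c1`. The change is carboxymethyl in place of 1-(methoxycarbonyl)ethyl on an amide-type nitrogen. For the measured compounds named here, two measured steps bear on it. The step of an at least 2.9-fold lower number from compound 1 to compound 3 (0.47 log units; beyond the scatter) trades the methyl ester of compound 1 for the free carboxylic acid while keeping the rest of the group. The step of an at least 14-fold lower number from compound 1 to compound 2 (1.14 log units; beyond the scatter) replaces the whole group on the amide-type nitrogen and is the larger of the two. Compound 4 carries the free acid as compound 3 does, but as carboxymethyl rather than 1-carboxyethyl, so the closer guide is the step to compound 3.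

A modest step downward, an at least 2.5-fold lower number from compound 1 to compound 4 (0.39 log units; beyond the scatter), is expected, because compound 3 gives 16800 nM. Compound 4 is therefore estimated at 20000 nM, with a range from 7000 nM to 60000 nM.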

Compound 4, half-maximal inhibitory concentration: 30100 nM
Compound 4: the middle estimate sits 1.5-fold (0.18 log units) below what was measured, and the stated range covers the measured number.
By their numbers in this assay, from the lowest: compound 2; then compounds 3 and 4 (each within the scatter of the next). At a limit, above all of these: compound 1.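

In this assay, the methyl on the saturated chain carbon, and with it the defined stereocentre, makes no difference that can be told apart between the two free acids (a 1.8-fold higher number from compound 3 to compound 4 (0.25 log units; within the scatter)). The change from 1-(methoxycarbonyl)ethyl to carboxymethyl on the amide-type nitrogen reads only as a floor (an at least 1.6-fold lower number from compound 1 to compound 4 (0.22 log units; that floor lies within the scatter)), and that floor rests on a limit and not on a number: the limit of > 50000 nM in this assay, at which 1 of the 4 values shown sits. Carboxymethyl also leaves the gap to the 1-(hydroxymethyl)cyclopropyl group in place (an 8.5-fold higher number from compound 2 to compound 4 (0.93 log units; beyond the scatter)), so with or without the chain methyl, the free acid on this nitrogen stays apart from compound 2.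

The compounds shown leave open whether the hydroxymethyl or the cyclopropyl ring of compound 2 carries that gap, which a plain 2-hydroxyethyl group on the same nitrogen would begin to separate. They also leave open how a longer chain ending in a carboxylic acid, or a primary amide in place of the acid, would read on the amide-type nitrogen.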